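The source may report more compounds than this note shows. Statements on the series, on what has been measured and on what is new or still open speak of the compounds shown alone.

Measured compounds: compound 1 `Cc1nnc(Sc2cc(NC(=O)c3ccc(Cl)cc3)c3ccccc3c2O)s1` and compound 2 `O=C(Nc1cc(Sc2ncn[nH]2)c(O)c2ccccc12)c1ccc(Cl)cc1`.

In a functional assay on HCT-116 cells (Homo sapiens) for antiproliferative activity, read by MTT assay, with a stated time of 48 h (on this read-out lower numbers stand for stronger inhibition and higher numbers for weaker inhibition), compound 1 gives > 100000 nM, which is a limit of the assay and not a number. In this assay, among the measured compounds shown here, compound 2 gives 43300 nM, the only number among the values shown. The step of an at least 2.3-fold lower number from compound 1 to compound 2 (0.36 log units; beyond the scatter) concerns the group on the sulfur, and compound 1 sits at the limit of > 100000 nM in this assay, at which 1 of the 2 values shown sits.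

Compound 3 `O=C(Nc1cc(Sc2ncn[nH]2)c(O)c2ccccc12)c1ccc2ccccc2c1` differs from compound 2 at another place: naphthalen-2-yl in place of 4-chlorophenyl on a carbonyl carbon. For the measured compounds named here, no measured step alters the group on the carbonyl carbon, so the single measured step offers no guide for this change, and the expectation rests on the number for compound 2 alone. The change is therefore expected to bring no shift beyond the scatter, a 1.1-fold lower number from compound 2 to compound 3 (0.03 log units; within the scatter). Compound 3 is expected to give about 40000 nM in this assay, in a range from 12000 nM to 130000 nM.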

Compound 3, half-maximal inhibitory concentration: > 100000 nM
Compound 3 ended at the assay's limit; the forecaster's own chance of this, stated with the estimate: 30%; middle value at least 2.5-fold (0.39 log units) from the limit.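

Naphthalen-2-yl in place of 4-chlorophenyl on a carbonyl carbon gives an at least 2.3-fold higher number from compound 2 to compound 3 (0.36 log units; beyond the scatter), so the group at this place, which no earlier step had touched, affects the read-out in this assay. Compound 3 gives > 100000 nM, which is a limit of the assay and not a number. Compound 2 now stands with single changes on either side of it, one on the sulfur and one on the carbonyl carbon, and both lead to compounds at the limit: the limit of > 100000 nM in this assay, at which 2 of the 3 values shown sit.

From the compounds shown here alone, how far compound 3 lies from compound 2 stays open, as does whether the difference goes with the second aromatic ring or with the absence of the chlorine. A plain phenyl on the carbonyl carbon, or a phenyl carrying a methoxy group or an amine, would bear on this, and the compounds shown cannot say how either would read.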